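Fluorinated Anilide on a Paw-Edema Acid Scaffold

This account rests on a few compounds, and the source may have more. Where it says the series, first, only, none or still open, it means among the compounds named here.

Of the compounds shown here, three sharing one core have been measured in a functional assay on the whole organism (strain C57BL/6) for inhibition, with Mus musculus as the target, read by paw edema, with stated times of 1 h and 4 h, at a dose of 100 mg/kg by the oral route; on this read-out lower numbers stand for less inhibition and higher numbers for more inhibition at the one dose given (going by the name of the read-out). The acid compound 1 `CC(=O)Nc1ccc(Cc2noc(CCC(=O)O)n2)cc1` gives 75.3%; the anilide compound 2 `CC(=O)Nc1ccc(Cc2noc(CCC(=O)Nc3ccccc3)n2)cc1` gives 34.2%; the methoxy-bearing anilide compound 3 `COc1ccccc1NC(=O)CCc1nc(Cc2ccc(NC(C)=O)cc2)no1` gives 87.7%. Compound 2 stands lowest of the three: a number 41.1 percentage points lower from compound 1 to compound 2 (beyond the scatter) and a number 53.5 percentage points higher from compound 2 to compound 3 (beyond the scatter), while a number 12.4 percentage points higher from compound 1 to compound 3 (beyond the scatter).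

The unmeasured compound 4 `CC(=O)Nc1ccc(Cc2noc(CCC(=O)Nc3ccc(F)cc3F)n2)cc1` differs from compound 2 in one place, (2,4-difluorophenyl in place of phenyl on an amide-type nitrogen). For the measured compounds named here, no measured step puts fluorine onto this ring, so the bearing steps are indirect. The step from compound 1 to compound 2 shows that an unsubstituted anilino sits well below the free acid, and the step from compound 2 to compound 3 shows that a single methoxy on that ring lifts inhibition by a large margin. A substituent on the aromatic ring thus appears to matter in this assay, but only one such substituent has been tried, and a methoxy is not a fluorine. The author therefore expects for compound 4 a rise beyond the scatter that is smaller and less certain than the methoxy step, and the expected step for compound 4 is a number 20.8 percentage points higher from compound 2 to compound 4 (beyond the scatter). The estimate for compound 4 in this assay is 55%, with a range from 28% to 82%.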

Compound 4, a percentage reported as inhibition, in the whole organism at one dose (the size of the read-out at that dose, not a potency): 52.1%
Compound 4: the middle estimate sits 2.9 percentage points above what was measured, within the range that was stated.
By their numbers in this assay, from the lowest: compound 2; then compound 4; then compound 1; then compound 3.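

In this assay, the amide-type nitrogen now carries a second kind of substituted phenyl: with 2,4-difluorophenyl in place of phenyl there is a number 17.9 percentage points higher from compound 2 to compound 4 (beyond the scatter), so a rise over the plain anilide is no longer seen with the methoxy alone. That rise stops well short of the methoxy-bearing anilide, with a number 35.6 percentage points lower from compound 3 to compound 4 (beyond the scatter), and the fluorinated anilide also stays under the free acid, with a number 23.2 percentage points lower from compound 1 to compound 4 (beyond the scatter), so the level of inhibition differs with which substituents the phenyl carries and not merely with whether it carries any. Nothing available on these compounds accounts for this difference.

The compounds shown leave open whether the lift needs both fluorines or would come with a single fluorine on the phenyl, and whether a chlorine or a trifluoromethyl group there would land nearer the plain anilide or the methoxy-bearing one. They also leave open how far these readings hold at other doses, since only one dose is given, and whether a longer chain between the shared core and the carbonyl would change the order of the anilides.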